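Cyclopentyl for methyl on the ketone chain

The compounds below may be only part of what the source reports. "The series", "measured", "known", "first", "only" and "open" are said of these compounds alone.

The two measured compounds share a core in which a four-carbon ether linker joins a hydroxylated aryl ketone to a benzoic acid. Compound 1 `Cc1c(OCCCCOc2ccc(C(=O)O)cc2Cl)ccc(C(=O)CC2CCCC2)c1O` gives 27.4% in an assay on HEK293 cells for positive allosteric modulation of metabotropic glutamate receptor 3 (Rattus norvegicus), read by thallium flux, with a stated time of 2.5 min; a lower number here means a smaller maximal response, a higher number a larger maximal response. Compound 2 `CCC(=O)c1ccc(OCCCCOc2ccc(F)c(C(=O)O)c2)c(C)c1O` gives 18.4% in this assay, and the gap between compound 2 and compound 1 lies within the usual scatter, so the two numbers tell the same story: a small maximal response for both.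

Compound 3 `Cc1c(OCCCCOc2ccc(F)c(C(=O)O)c2)ccc(C(=O)CC2CCCC2)c1O` keeps the fluoro benzoic acid of compound 2 and changes the ketone side: cyclopentyl in place of methyl on a saturated chain carbon bound to a carbonyl carbon. The same group on the ketone side is present in compound 1, whose value sits close to that of compound 2, which gives no sign that this change moves the response beyond the scatter. The step from compound 2 to compound 3 is therefore expected to be small, with no clear direction, as a number 5.6 percentage points higher from compound 2 to compound 3 (within the scatter) in this assay. Compound 3 is estimated at 24%, within a range from 10% to 40%.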

Compound 3, largest response reached (reported as percent of maximum), in percent of the reference or control that the assay uses: 98.4%
For compound 3 the middle estimate is 74.4 percentage points below the measured one, and the stated range ends below it.
By their numbers in this assay, from the lowest: compounds 2 and 1 (each within the scatter of the next); then compound 3.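

With the 3-carboxy-4-fluorophenyl held in place, cyclopentyl in place of methyl on a saturated chain carbon bound to a carbonyl carbon gives a number 80 percentage points higher from compound 2 to compound 3 (beyond the scatter) in this assay, so this position on the ketone side can carry a large change in maximal response. Cyclopentyl alone does not produce that response among these compounds: with cyclopentyl kept, 3-carboxy-4-fluorophenyl in place of 4-carboxy-2-chlorophenyl on an oxygen on a saturated carbon gives a number 71 percentage points higher from compound 1 to compound 3 (beyond the scatter), so the high value appears only where the two groups occur together. Nothing given here accounts for the size of either step.

The compounds shown leave open whether the rise belongs to cyclopentyl itself or would also follow from another group at this place, such as cyclohexyl, phenyl or a branched isopropyl. They also leave open how far the pairing with the acid ring extends, for instance to a chlorine in place of the fluorine on the 3-carboxyphenyl, or to a longer chain in the ether linker.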